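A few compounds are considered here, and "the series" means these few. Any claim that something is new, unique, unknown or untested is made for them only; others in the source may bear on it.

Within the data shown here, compound 2 `Cc1cc(O)c(C(C)C)cc1-c1cc(-c2ccccc2[N+](=O)[O-])c(C#N)c(=O)[nH]1` is one of two compounds measured so far in a functional assay for inhibition, tested at 40 ug/mL; a lower number here means a weaker effect, a higher number a stronger effect of the compound at the concentration tested. Compound 2 gives 25.5%, the lowest of the two numbers shown, and compound 1 `Cc1cc(O)c(C(C)C)cc1-c1cc(-c2ccccc2)c(C#N)c(=O)[nH]1` gives 29%, which lies within the scatter of it. Compound 3 `Cc1cc(O)c(C(C)C)cc1-c1cc(-c2ccccc2Cl)c(C#N)c(=O)[nH]1` has not yet been measured. Compound 3 differs from compound 2 in one place: chloro in place of nitro on an aromatic carbon. Among the measured compounds shown here, the only measured step, a number 3.5 percentage points lower from compound 1 to compound 2 (within the scatter), concerns a different change and stays within the scatter, so it offers no guidance on replacing nitro by chloro, and no measured pair shows what chloro does on this core. On these data the expected step is a number 1.5 percentage points higher from compound 2 to compound 3 (within the scatter), none beyond the scatter. Compound 3 is therefore estimated to give 27% in this assay, within a range from 14% to 40%.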

Compound 3, a percentage reported as inhibition, at one concentration (the size of the read-out at that concentration, not a potency): 20%
For compound 3 the middle estimate is 7 percentage points above the measured one; low and high end bracket the measured number.
By their numbers in this assay, from the lowest: compounds 3, 2 and 1 (each within the scatter of the next).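

In this assay, chloro can now be set against both nitro and hydrogen at this position, ortho to a large group: exchanging nitro for chloro gives a number 5.5 percentage points lower from compound 2 to compound 3 (within the scatter), and chloro in place of hydrogen gives a number 9 percentage points lower from compound 1 to compound 3 (within the scatter). All three compounds therefore lie within the scatter of one another, so this position has so far shown no measurable preference among hydrogen, nitro and chloro. No independent measurement is available to explain these small differences.

As far as these compounds go, whether an amine, a carboxylic acid or a methoxy group at this position would move the read-out beyond the scatter stays open. Also open, from the compounds shown here alone, is how chloro or nitro would read on other carbons of this aromatic ring, and a read-out at a single concentration does not give a potency.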